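Working notes: unsubstituted aryl analogue, compound 3

The compounds below may be only part of what the source reports. "The series", "measured", "known", "first", "only" and "open" are said of these compounds alone.

Measured so far:
compound 1 `N=C(NO)N/N=C/c1ccc(O)cc1` — > 100000 nM
compound 2 `CN(C)c1ccc(/C=N/NC(=N)NO)cc1` — > 100000 nM

In a functional assay on HL-60 cells (Homo sapiens) for antiproliferative activity (on this read-out higher numbers stand for weaker inhibition and lower numbers for stronger inhibition), compound 1 gives > 100000 nM, which is a limit of the assay and not a number. In this assay compound 2 gives > 100000 nM, likewise a limit. The step that the two limits leave unreadable from compound 1 to compound 2 therefore cannot be sized. Compound 2 stands at the limit of > 100000 nM in this assay, at which 2 of the 2 values shown sit, with no number to place it relative to anything else in the series.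

Compound 3 `N=C(NO)N/N=C/c1ccccc1` differs from compound 2 by hydrogen in place of dimethylamino on an aromatic carbon. Among the compounds with values here, the only measured step that bears on a change at this position is a step that the two limits leave unreadable from compound 1 to compound 2, and it is unreadable, so it gives neither a size nor a direction for this assay. With both measured compounds at the limit, there is nothing to suggest that removing the dimethylamino group should move the read-out into the measurable range. The expected step that the limit leaves unreadable from compound 2 to compound 3 is none beyond the scatter, with the strong likelihood that compound 3 again returns only a limit. Compound 3 is therefore estimated at 150000 nM, in the range 50000 nM to 500000 nM.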

Compound 3, half-maximal inhibitory concentration: 62000 nM
For compound 3 the middle estimate is 2.4-fold (0.38 log units) above the measured one, within the range that was stated.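

In this assay compound 3, with hydrogen at this position on the aromatic carbon, is the only compound shown that returns a number, while the other two compounds stay at a limit of the assay: the limit of > 100000 nM in this assay, at which 2 of the 3 values shown sit.

Hydrogen in place of dimethylamino gives an at least 1.6-fold lower number from compound 2 to compound 3 (0.20 log units; that floor lies within the scatter), and hydrogen in place of hydroxy gives an at least 1.6-fold lower number from compound 1 to compound 3 (0.20 log units; that floor lies within the scatter), so both substituents can now be set against the same unsubstituted compound. These are floors and not sizes, so neither one settles whether losing the substituent matters beyond the scatter, and the step between compound 1 and compound 2 still cannot be read.

The compounds shown leave open how far compound 1 and compound 2 really lie from compound 3, and whether any group at this position gives a lower number than hydrogen does, for example a chlorine atom, a methoxy group or a carboxylic acid. They also leave open whether a change elsewhere in the shared core, away from this position, would move the read-out at all.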